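Chloro in place of hydroxy on the aryl ketone

A few compounds are considered here, and "the series" means these few. Any claim that something is new, unique, unknown or untested is made for them only; others in the source may bear on it.

In a functional assay on NCI/ADR-RES cells (Homo sapiens) for cytotoxicity, read by sulforhodamine B assay, with a stated time of 24 h (on this read-out higher numbers stand for weaker inhibition of growth and lower numbers for stronger inhibition of growth), compound 1 `COc1ccc(C(=O)/C=C/c2cc3ccccc3[nH]c2=O)cc1` gives 8440 nM. Compound 2 `O=C(/C=C/c1cc2ccccc2[nH]c1=O)c1ccc(O)cc1` sits at the limit of > 100000 nM in this assay, at which 1 of the 2 values shown sits, so in this assay compound 2 gives > 100000 nM, a limit and not a number. Compound 3 `O=C(/C=C/c1cc2ccccc2[nH]c1=O)c1ccc(Cl)cc1` carries chloro in place of hydroxy on an aromatic carbon. For the measured compounds named here, the only measured step, an at least 11-fold higher number from compound 1 to compound 2 (1.07 log units; beyond the scatter), was large and concerned methyl to hydrogen on the ring oxygen; no measured step covers chloro. Chloro again removes the hydroxy. Compound 3 is therefore expected to come back down from the limit, estimated at 12000 nM with a range of 3000 nM to 60000 nM. The expected step is an at least 8.3-fold lower number from compound 2 to compound 3 (0.92 log units; beyond the scatter).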

Compound 3, concentration for total growth inhibition: 23600 nM
The estimate for compound 3 lay 2.0-fold (0.29 log units) below the measured number, within the range that was stated.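

Chloro brings measurable growth inhibition back at this position, with an at least 4.2-fold lower number from compound 2 to compound 3 (0.62 log units; beyond the scatter). Compound 2 is held at a limit and not a number, so that step has no upper bound: the limit of > 100000 nM in this assay, at which 1 of the 3 values shown sits. Chloro does not match methoxy, however, with a 2.8-fold higher number from compound 1 to compound 3 (0.45 log units; beyond the scatter), leaving compound 1 the most potent of the three.

From the compounds shown here alone, how an amine, a carboxylic acid or a longer chain such as ethoxy would read at this position stays open. The three compounds also cannot show why methoxy and chloro differ.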